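Swapping Chloro for Fluoro on Two Related Cores

The compounds below may be only part of what the source reports. "The series", "measured", "known", "first", "only" and "open" are said of these compounds alone.

Compound 1 `C[C@@]1(O)[C@H](O)[C@@H](CO)O[C@H]1c1cc(Cl)c2c(N)ncnn12` was tested in an ADME assay on Huh-7 cells (Homo sapiens) for cytotoxicity (on this read-out lower numbers stand for higher toxicity in this test and higher numbers for lower toxicity in this test), where compound 1 gives 6500 nM. Compound 2 `C[C@@]1(O)[C@H](O)[C@@H](CO)O[C@H]1c1cc(F)c2c(N)ncnn12` differs from it by fluoro in place of chloro on an aromatic carbon. In this assay compound 2 reaches only a limit, > 100000 nM. That step is an at least 15-fold higher number from compound 1 to compound 2 (1.18 log units; beyond the scatter), which rests on (the limit of > 100000 nM in this assay, at which 2 of the 3 values shown sit). Compound 3 `C[C@@]1(O)[C@H](O)[C@@H](CO)O[C@H]1c1cnc2c(N)nc(Cl)nn12` carries a different core; how the two cores differ is not broken down here. In this assay compound 3 likewise gives only a limit, > 100000 nM. Compound 4 `C[C@@]1(O)[C@H](O)[C@@H](CO)O[C@H]1c1cnc2c(N)nc(F)nn12` differs from compound 3 by fluoro in place of chloro on an aromatic carbon. This is the same kind of change as before, but here it sits on a six-membered aromatic ring with 3 nitrogen, between two ring nitrogen atoms, rather than on a five-membered aromatic ring with 1 nitrogen. The earlier step of an at least 15-fold higher number from compound 1 to compound 2 (1.18 log units; beyond the scatter) points toward less toxicity. For compound 3, already at a limit, the expected step is a step that the limit leaves unreadable from compound 3 to compound 4. Compound 4 is therefore estimated to come out near 150000 nM, most likely again reported as a limit.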

Compound 4, half-maximal cytotoxic concentration: > 100000 nM
Compound 4 gave a limit, no number (the forecaster's own chance of this, stated with the estimate: 90%); the middle value is on the limit's open side.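

In this assay, among the compounds shown here, compound 3 and compound 4 both end at a limit, so no step between them can be read: (the limit of > 100000 nM in this assay, at which 3 of the 4 values shown sit). From the compounds shown here alone, whether fluoro in place of chloro changes the cytotoxic concentration on this core remains open.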